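Swapping One Ring Group on a Growth Inhibitor

The source may report more compounds than this note shows. Statements on the series, on what has been measured and on what is new or still open speak of the compounds shown alone.

- compound 1 `COc1ccccc1/C=C(/SCc1ccc(Cl)cc1)C(=O)c1ccc([N+](=O)[O-])cc1`: 10000 nM
- compound 2 `COc1ccccc1/C=C(/SCc1ccc(Cl)cc1)C(=O)c1ccc(Cl)cc1`: 1000 nM
- compound 3 `COc1ccccc1/C=C(/SCc1ccc(C)cc1)C(=O)c1ccc(Cl)cc1`: 10000 nM

In a functional assay on DU-145 cells (Homo sapiens) for inhibition, read by trypan blue exclusion, with a stated time of 96 h (on this read-out lower numbers stand for stronger inhibition of growth and higher numbers for weaker inhibition of growth), compound 2 gives 1000 nM, the lowest of the three numbers and so the strongest growth inhibition measured in this small set. Compound 4 `Cc1cc(C)cc(/C=C(/SCc2ccc(Cl)cc2)C(=O)c2ccc(Cl)cc2)c1` keeps the rest of compound 2 but carries 3,5-dimethylphenyl in place of 2-methoxyphenyl on a double-bonded chain carbon bound to a double-bonded chain carbon.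

Two measured steps offer some guidance. The first is a 10-fold lower number from compound 1 to compound 2 (1.00 log units; beyond the scatter), with chloro in place of nitro on an aromatic carbon. The second is a 10-fold higher number from compound 2 to compound 3 (1.00 log units; beyond the scatter), with methyl in place of chloro on an aromatic carbon. Both lie beyond the scatter, so a single swap in this series can move the number clearly. For the measured compounds named here, neither touches the group that changes here, however, and no measured compound varies that group, so they indicate only a plausible size, not a direction.

Compound 2 already holds the lowest number, so a rise seems slightly more likely than a fall in this assay. The estimated step is a 2.0-fold higher number from compound 2 to compound 4 (0.30 log units; within the scatter), a small rise with wide uncertainty. The estimate for compound 4 is 2000 nM, with an expected range from 400 nM to 10000 nM.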

Compound 4, concentration for 50% growth inhibition: 10000 nM
The estimate for compound 4 lay 5.0-fold (0.70 log units) below the measured number; the measured number falls inside the stated range.
By their numbers in this assay, from the lowest: compound 2; then compounds 1, 3 and 4 (each within the scatter of the next).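

This is the first change shown at this position, the aryl group on a double-bonded chain carbon bound to a double-bonded chain carbon, and in this assay replacing 2-methoxyphenyl with 3,5-dimethylphenyl gives a 10-fold higher number from compound 2 to compound 4 (1.00 log units; beyond the scatter), so a single swap here can move the number clearly, as swaps at the two other places did. The counts show what this swap does and does not alter: both groups have 8 heavy atoms and one six-membered aromatic ring of carbon only, while the oxygen and its hydrogen-bond acceptor leave and carbon takes over, yet the removal of the methoxy group and the arrival of the two methyl groups happen together, so their shares in the rise cannot be separated. No measurement available here explains the rise.

Still open, as far as these compounds go, is whether the loss follows from removing the methoxy group or from adding the methyl groups, a question that plain phenyl, 2-methylphenyl or 3,5-dimethoxyphenyl at this place could help to answer. From the compounds shown here alone, it is also open how this position would respond to a ring carrying an amine or a carboxylic acid.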